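Methoxy for fluoro on a thiazolethione aryl ring

This account rests on a few compounds, and the source may have more. Where it says the series, first, only, none or still open, it means among the compounds named here.

In an assay on isolated protein for inhibition of Indoleamine 2,3-dioxygenase 1 (Homo sapiens), read by colorimetric assay, with stated times of 10 min and 30 min, tested at 100 uM (on this read-out lower numbers stand for less inhibition and higher numbers for more inhibition at the one concentration tested (going by the name of the read-out)), compound 1 `Fc1ccccc1-c1c[nH]c(=S)s1` gives 29%, the lowest of the two numbers recorded, while compound 2 `COc1ccccc1-c1csc(=S)[nH]1` gives 53% in this assay, a gap that lies beyond the usual scatter. Compound 3 `COc1ccccc1-c1c[nH]c(=S)s1` is not yet measured. It differs from compound 1 in one place: methoxy in place of fluoro on an aromatic carbon. Within the data shown here, no step between measured compounds of this kind exists, so compound 3 is expected to move by a number 11 percentage points higher from compound 1 to compound 3 (beyond the scatter), a modest rise that stays uncertain. Compound 3 is estimated to give 40%, with a range from 22% to 60%.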

Compound 3, a percentage reported as inhibition, at one concentration (the size of the read-out at that concentration, not a potency): 12%
Compound 3: middle estimate off by 28 percentage points, on the high side; measured number outside the range, below it.
By their numbers in this assay, from the lowest: compound 3; then compound 1; then compound 2.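

In this assay, among these compounds, methoxy in place of fluoro on this aromatic carbon brings a number 17 percentage points lower from compound 1 to compound 3 (beyond the scatter), the first reading of this change on the core of compound 1. It shows that the number changes with the group placed there, and that for this pair the number is lower with methoxy than with fluoro. No measurement at hand accounts for the fall. The compounds shown leave open how an amine, a carboxylic acid or a longer chain on this carbon would read, and whether a ring carrying no group there would stand above or below compound 1.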